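Chloro for ethoxy on the aryl of compound 1

The compounds below may be only part of what the source reports. "The series", "measured", "known", "first", "only" and "open" are said of these compounds alone.

Three compounds carry numbers in a physicochemical assay for lipophilicity; on this read-out lower numbers stand for lower lipophilicity and higher numbers for higher lipophilicity. Compound 1 `CCOc1ccccc1-c1nc(N)nc(N)n1` gives 1.03; compound 2 `CCn1c(=O)c(N(C)C)c(C)n(-c2ccccc2)c1=O` gives 2.29; compound 3 `Cc1c(N(C)C)c(=O)n(CCO)c(=O)n1-c1ccccc1` gives 1.12. Compound 1 sits at the low end of the three numbers: compound 3 lies within the scatter of it, while compound 2 lies beyond the scatter above it. Among the measured compounds shown here, the only step between two measured compounds that differ in one place is a number 1.17 log units lower from compound 2 to compound 3 (beyond the scatter), a change on a different core and of a different kind, so it does not bear directly on the present step.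

Compound 4 `Nc1nc(N)nc(-c2ccccc2Cl)n1` differs from compound 1 in one place: chloro in place of ethoxy on an aromatic carbon. For the measured compounds named here, no measured pair shows a chloro entering or an ethoxy leaving, so the expectation rests only on the change itself, a three-atom group with one hydrogen-bond acceptor giving way to a single chlorine. A modest rise in this assay is expected, close to the scatter. Compound 4 is expected to give 1.35, within 0.9 to 1.8. That estimate means an expected step of a number 0.32 log units higher from compound 1 to compound 4 (beyond the scatter).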

Compound 4, partition coefficient: 1.19
Estimate against measurement, compound 4: 0.16 log units above, and the stated range covers the measured number.
By their numbers in this assay, from the lowest: compounds 1, 3 and 4 (each within the scatter of the next); then compound 2.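

In this assay, among the compounds shown here, the exchange of ethoxy for chloro on an aromatic carbon of the core of compound 1 amounts to a number 0.16 log units higher from compound 1 to compound 4 (within the scatter) and is the first step read on this core. On this read-out, compound 1 and compound 4 cannot be told apart, even though ethoxy, with its 3 heavy atoms and 1 hydrogen-bond acceptor, gives way to chloro, with 1 heavy atom and no hydrogen-bond acceptor. No available evidence accounts for how close these two compounds lie.

The compounds shown leave open whether other groups on this aromatic carbon, such as methoxy, fluoro, an amine or a longer alkoxy chain, would also stay within the scatter of compound 1. Going by these compounds, whether chloro in place of ethoxy would give a similar step on another core also remains open.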